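From compound 3 to compound 4: one large addition

This account rests on a few compounds, and the source may have more. Where it says the series, first, only, none or still open, it means among the compounds named here.

In a functional assay on MDA-MB-231 cells (Homo sapiens) for inhibition, read by MTT assay, with a stated time of 48 h (on this read-out lower numbers stand for stronger inhibition of growth and higher numbers for weaker inhibition of growth), compound 3 (`S=C(Nc1ccccc1)Nc1ccc2ncnc(Nc3cccc(Br)c3)c2c1`) gives 10000 nM and lies within the scatter of compound 1 (`CCc1cccc(Nc2ncnc3ccc(NC(=S)NCc4ccccc4)cc23)c1`) at 10500 nM on the same read-out. Compound 2 (`N=C(N)NS(=O)(=O)c1ccc(Nc2ncnc3ccc(NC(=S)NCc4ccccc4)cc23)cc1`) gives > 30000 nM, which is a limit and not a number. Compound 4 (`O=S(=O)(Nc1nccs1)c1ccc(NC(=S)Nc2ccc3ncnc(Nc4cccc(Br)c4)c3c2)cc1`) is compound 3 with (1,3-thiazol-2-yl)sulfamoyl in place of hydrogen on an aromatic carbon, para to a large group ((1,3-thiazol-2-yl)sulfamoyl in place of hydrogen on an aromatic carbon). Within the data shown here, no measured pair shows a comparable change, so any expectation is loose. The one hint of weaker inhibition is compound 2, again a limit at > 30000 nM. A modest weakening is therefore expected in this assay, an estimated 1.4-fold higher number from compound 3 to compound 4 (0.15 log units; within the scatter). For compound 4 the expected value is 14000 nM, with an estimated range of 5000 nM to 30000 nM.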

Compound 4, concentration for 50% growth inhibition: > 30000 nM
Compound 4: only a limit was reported (the forecaster's own chance of this, stated with the estimate: 25%); at least 2.1-fold (0.33 log units) between middle value and limit.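

In this assay, among these compounds, placing (1,3-thiazol-2-yl)sulfamoyl on this aromatic carbon, para to a large group, gives an at least 3.0-fold higher number from compound 3 to compound 4 (0.47 log units; beyond the scatter), the first readable step between compounds that differ in one place. Compound 4 gives > 30000 nM, which is a limit and not a number. The true size of the step stays unknown because the reading ends at a limit: the limit of > 30000 nM in this assay, at which 2 of the 4 values shown sit.

Still open, going by these compounds, is whether the weakening comes from the whole addition or from one part of it, such as its five-membered aromatic ring. On these data alone, it is also open whether a plain amine or a carboxylic acid on the same carbon would weaken growth inhibition too.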